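A few compounds are considered here, and "the series" means these few. Any claim that something is new, unique, unknown or untested is made for them only; others in the source may bear on it.

Working notes on the series.

Three compounds stand measured in a physicochemical assay for acid dissociation. Compound 1, `COc1ccc(F)cc1CNCCCNc1ccnc2cc(C3CCCCC3)ccc12`, gives 9.47. Compound 2, `COc1cccc(CNCCCNc2ccnc3cc(-c4ccc(F)cc4)ccc23)c1O`, gives 9.47. Compound 3, `c1ccc(CCc2ccc3c(NCCCNCc4ccco4)ccnc3c2)cc1`, gives 9.47. At the digits shown compound 3 is level with compound 1 and with compound 2; both lie within the scatter of it, so no order among the three can be read from these numbers. The three differ considerably in their aromatic parts, yet the read-out is the same.

Compound 4, `COc1ccc(-c2ccc3c(NCCCNCc4ccco4)ccnc3c2)cc1`, is the next point and is not yet measured. It differs from compound 3 in one place: 4-methoxyphenyl in place of phenethyl on an aromatic carbon. The change is on the fused ring system, with the 4-methoxyphenyl entering at the aromatic carbon described and the phenethyl leaving; the chain carrying the amines is untouched.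

Within the data shown here, no step between measured compounds is available. Given that compound 1, compound 2 and compound 3 coincide in this assay despite different aromatic groups, the step of no change at the digits printed from compound 3 to compound 4 (within the scatter) is expected to be none beyond the scatter. Compound 4 is thus estimated at 9.47, with a range from 9.15 to 9.8.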

Compound 4, acid dissociation constant: 9.47
Compound 4: middle estimate and measured number agree at the digits printed, within the range that was stated.
By their numbers in this assay, from the lowest: compounds 1, 2, 3 and 4 (each within the scatter of the next).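

In this assay, 4-methoxyphenyl in place of phenethyl on an aromatic carbon gives no change at the digits printed from compound 3 to compound 4 (within the scatter). Among these compounds, this is the first reading of a change at a single place, whereas the earlier compounds could only be set side by side with several parts differing at once; at this position, a group bringing one hydrogen-bond acceptor replaces one with none, with the same heavy-atom count, and the read-out does not move beyond the scatter. Nothing available bears on why the read-out stays as it does.

The compounds shown leave open whether this holds with a carboxylic acid or a primary amine on that aromatic carbon. From the compounds shown here alone, all four share the chain carrying the amines, so what a longer chain there would do also remains open.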